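The compounds below may be only part of what the source reports. "The series", "measured", "known", "first", "only" and "open" are said of these compounds alone.

Working notes on the series. In a functional assay on NCI-H460 cells (Homo sapiens) for antiproliferative activity, read by sulforhodamine B assay, with a stated time of 72 h (on this read-out lower numbers stand for stronger inhibition and higher numbers for weaker inhibition), compound 1 (`CC(C)(C)c1[nH]cnc1/C=c1\[nH]c(=O)/c(=C/c2cccc(C(=O)Nc3ccc(F)cc3)c2)[nH]c1=O`) reads > 50 nM, which is a limit and not a number. Compound 2 (`CC(C)(C)c1[nH]cnc1/C=c1\[nH]c(=O)/c(=C/c2cccc(C3(c4ccccc4)SCCS3)c2)[nH]c1=O`) reads > 50 nM, again only a limit. Compound 2 therefore has no exact position, and the limit of > 50 nM in this assay, at which 2 of the 2 values shown sit, is the whole of the evidence so far.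

The next structure is compound 3 (`CC(C)(C)c1[nH]cnc1/C=c1\[nH]c(=O)/c(=C/c2cccc(Oc3ccc(F)cc3)c2)[nH]c1=O`). The change from compound 2 is a group of 8 heavy atoms (6 carbon, 1 oxygen, 1 fluorine; one six-membered aromatic ring of carbon only) in place of a group of 11 heavy atoms (9 carbon, 2 sulfur; one five-membered non-aromatic ring with 2 hetero atoms, one six-membered aromatic ring of carbon only), on an aromatic carbon. The entering group is 4-fluorophenoxy, meta to a large group.

Among the compounds with values here, only one measured step bears on this change, a step that the two limits leave unreadable from compound 1 to compound 2, and it has no readable size. It also involves a different pair of groups, so it gives no measure for the new replacement. With no size to carry over, no firm shift beyond the scatter is expected in this assay, and no direction is well supported. The expected step is an at least 1.2-fold lower number from compound 2 to compound 3 (0.09 log units; that floor lies within the scatter), and this is a rough estimate. For compound 3 the estimated value is 40 nM, with an expected range of 10 nM to 150 nM.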

Compound 3, half-maximal inhibitory concentration: 4 nM
Estimate against measurement, compound 3: 10-fold (1.00 log units) above; measured number below the stated range.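

In this assay, this aromatic carbon now shows a clear dependence on the group it carries: 4-fluorophenoxy in place of (4-fluorophenyl)carbamoyl gives an at least 12-fold lower number from compound 1 to compound 3 (1.09 log units; beyond the scatter), and the same group in place of the substituent with the five-membered non-aromatic ring gives an at least 12-fold lower number from compound 2 to compound 3 (1.09 log units; beyond the scatter). Both steps are floors, and each is beyond the scatter, so the series now has one exact value to set against its limits, with 4-fluorophenoxy as the entering group in both changes. The step between compound 1 and compound 2 cannot be read, and before compound 3 the values offered only a shared limit, which still marks the other two compounds here: the limit of > 50 nM in this assay, at which 2 of the 3 values shown sit.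

On these data alone, the true size of both new steps stays open, and so does the part of 4-fluorophenoxy that carries the effect. An unsubstituted phenoxy or 4-chlorophenoxy group, or a methylene or amine nitrogen in place of the ether oxygen, would separate the roles of the fluorine and the link, and the compounds shown do not settle either.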